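This account rests on a few compounds, and the source may have more. Where it says the series, first, only, none or still open, it means among the compounds named here.

Three compounds have been measured in an assay on isolated protein for inhibition of tyrosine-protein kinase receptor UFO (Homo sapiens), read by LC-MS; on this read-out lower numbers stand for stronger inhibition and higher numbers for weaker inhibition:

compound 1, `COc1ccccc1-c1ccc(-c2nnc(N(C)Cc3ccc4nccn4c3)o2)cc1`, gives 1580 nM
compound 2, `Cc1ccccc1-c1ccc(-c2nnc(N(C)Cc3ccc4nccn4c3)o2)cc1`, gives 631 nM
compound 3, `COc1cc(-c2c(C)nn(C)c2C)ccc1-c1nnc(N(C)Cc2ccc3nccn3c2)o1`, gives 794 nM

Compounds 1 and 2 share one core and differ in a single spot: methyl in place of methoxy on an aromatic carbon. This change gave a 2.5-fold lower number from compound 1 to compound 2 (0.40 log units; beyond the scatter). Compound 3 is built on a different core; how that core differs from the core of compound 1 is not broken down here. Its value sits within the usual scatter of both compound 2 and compound 1, so no order can be read among those pairs.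

Compound 4, `Cc1cc(-c2c(C)nn(C)c2C)ccc1-c1nnc(N(C)Cc2ccc3nccn3c2)o1`, has not yet been measured. It differs from compound 3 by methyl in place of methoxy on an aromatic carbon. Going by the values given here, this is the same kind of change as the one from compound 1 to compound 2, though the surroundings are not identical: in compound 3 the changed carbon is also meta to a 1,3,5-trimethyl-1H-pyrazol-4-yl group. Because of a 2.5-fold lower number from compound 1 to compound 2 (0.40 log units; beyond the scatter), a step of similar size is expected in this assay, namely a 2.3-fold lower number from compound 3 to compound 4 (0.36 log units; beyond the scatter). For compound 4 the estimate in this assay is therefore 350 nM, expected to fall between 150 nM and 800 nM.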

Compound 4, half-maximal inhibitory concentration: 79.4 nM
Compound 4: the middle estimate sits 4.4-fold (0.64 log units) above what was measured; the measured number lies below the stated range.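

On the core of compound 3, putting methyl in place of methoxy gave a 10-fold lower number from compound 3 to compound 4 (1.00 log units; beyond the scatter) in this assay. The direction of the step therefore carried over from the core of compound 1, but its size did not: the same change on two cores in this assay, a 2.5-fold lower number (0.40 log units; beyond the scatter) from compound 1 to compound 2 and a 10-fold lower number (1.00 log units; beyond the scatter) from compound 3 to compound 4, 4.0-fold (0.60 log units) apart, beyond the scatter of two such steps. Two pairs show that the size of this step can depend on the core, but they do not show why, and they give no way to predict the step on a third core; the 1,3,5-trimethyl-1H-pyrazol-4-yl group is one difference in the surroundings, yet these pairs cannot tie the gap to that group or to any other feature.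

Going by these compounds, it remains open how an ethyl group, a chlorine atom or a plain hydrogen on the same aromatic carbon would compare with methyl. On these data alone, it is also open whether such groups would show the same dependence on the core, which would need matching pairs on both cores.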